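An Aromatic Ester Replaces the Propargylamino Group

The source may report more compounds than this note shows. Statements on the series, on what has been measured and on what is new or still open speak of the compounds shown alone.

Compound 1, `CCN(CC)CCCNC(=O)c1ccc(C(CC)(CC)c2ccc(OCC(=O)C(C)(C)C)c(C)c2)n1CC`, has been tested in a functional assay on MCF7 cells (Homo sapiens), read by MTT assay, with a stated time of 48 h (a lower number here means a stronger inhibitor, a higher number a weaker inhibitor), and compound 1 gives 530 nM. Compound 2, `C#CCNC(=O)c1ccc(C(CC)(CC)c2ccc(OCC(O)C(C)(C)C)c(C)c2)n1CC`, is the second measured compound. In this assay compound 2 reaches only > 50000 nM, which is a limit of the assay and not a number. That is the limit described by the limit of > 50000 nM in this assay, at which 1 of the 2 values shown sits. Compound 3, `CCn1c(C(=O)Oc2ccc(CCO)cc2)ccc1C(CC)(CC)c1ccc(OCC(O)C(C)(C)C)c(C)c1`, has not yet been measured. It differs from compound 2 in one place: a group of 10 heavy atoms (8 carbon, 2 oxygen; one six-membered aromatic ring of carbon only) in place of a group of 4 heavy atoms (3 carbon, 1 nitrogen; no ring), on a carbonyl carbon. The group that leaves is the propargylamino group, and the group that enters is a larger one carrying one six-membered aromatic ring of carbon only, placed on the carbonyl carbon whose other neighbour is an aromatic carbon. The two measured compounds differ in more than one place. Among the compounds with values here, no single measured step is available to guide the size of this change. In this assay the step of an at least 1.6-fold lower number from compound 2 to compound 3 (0.22 log units; that floor lies within the scatter) is expected to be a modest gain, if any, beyond the scatter. Compound 3 is therefore estimated at 30000 nM, within a range from 5000 nM to 100000 nM.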

Compound 3, half-maximal inhibitory concentration: > 50000 nM
Compound 3: a limit, no number (the forecaster's own chance of this, stated with the estimate: 50%); middle value at least 1.6-fold (0.22 log units) away from the limit.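

In this assay compound 3 gives > 50000 nM as a limit of the assay and not a number. Within the data shown here, no step from compound 2 to compound 3 can be read, because both compounds sit at the same limit: the limit of > 50000 nM in this assay, at which 2 of the 3 values shown sit. The compounds shown leave open whether swapping the propargylamino group for the larger aromatic group changes inhibition at all.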